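Swapping a urea for an amide on an inactive series

The source may report more compounds than this note shows. Statements on the series, on what has been measured and on what is new or still open speak of the compounds shown alone.

Compound 3, with the structure `COc1cc(-c2nn(-c3cccc(NC(=O)Nc4cccc(C(F)(F)F)c4)c3)cc2-c2ccncc2)ccc1Cl`, carries a urea linker on the shared core. In a functional assay on DU-145 cells (Homo sapiens) for inhibition, read by sulforhodamine B assay, with a stated time of 48 h (a higher number here means that more compound is tolerated, a lower number that less compound is tolerated), compound 3 gives only a limit, > 50000 nM, so no true number is known for it. Compound 1, whose structure is `COc1cc(-c2nn(-c3cccc(NC(=O)c4cccc(C(F)(F)F)c4)c3)cc2-c2ccncc2)ccc1Cl`, is the amide relative; in this assay compound 1 likewise gives only the limit > 50000 nM. Compound 2, with the structure `COc1cc(-c2nn(-c3cccc(NC(=O)Nc4ccc(Cl)c(Cl)c4)c3)cc2-c2ccncc2)ccc1Cl`, is a second urea; in this assay compound 2 also gives only the limit > 50000 nM. Because of this, the steps that connect these three are written as a step that the two limits leave unreadable from compound 1 to compound 3 and a step that the two limits leave unreadable from compound 2 to compound 3, and neither can be sized, as the limit of > 50000 nM in this assay, at which 3 of the 3 values shown sit, states.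

The step to compound 4, whose structure is `COc1cc(-c2nn(-c3cccc(NC(=O)c4ccc(Cl)c(C(F)(F)F)c4)c3)cc2-c2ccncc2)ccc1Cl`, is 4-chloro-3-(trifluoromethyl)phenyl in place of (3-(trifluoromethyl)phenyl)amino on a carbonyl carbon. It is very close to the change behind the step from compound 1 to compound 3, read backwards, with one extra chlorine on the entering ring. With every measured value sitting at the same limit, no direction or size can be read, and the expected step is a step that the limit leaves unreadable from compound 3 to compound 4, which is no change beyond the scatter. Compound 4 is therefore expected to also reach only the limit, with an estimate of 60000 nM and a range from 20000 nM to 200000 nM.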

Compound 4, concentration lethal to 50% of the cells: > 32500 nM
Compound 4 ended at the assay's limit (the forecaster's own chance of this, stated with the estimate: 85%); the middle value lies beyond the limit too.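

Among the compounds shown here, all four compounds give only limits, not numbers, so no step from compound 1, compound 2 or compound 3 to compound 4 can be read. The compounds shown leave open whether any amide or urea on the shared core reaches a true value in this assay, and how these four would rank.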